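The source may hold more compounds than are shown below. What is called first, only, known or untested is meant among the compounds shown, and "the series" means these compounds.

The series keeps one shared core and varies the substituent on an amide-type nitrogen. Compound 1 `CNC(=O)c1cc(Oc2cccc(NC(=S)Nc3cccc(C(F)(F)F)c3)c2)ccn1` carries methyl on that nitrogen, and in a functional assay on HCT-116 cells (Homo sapiens) for cytotoxicity, read by MTT assay, with a stated time of 48 h (on this read-out higher numbers stand for weaker inhibition and lower numbers for stronger inhibition), compound 1 gives 25300 nM. Compound 2 `O=C(NC1CC1)c1cc(Oc2cccc(NC(=S)Nc3cccc(C(F)(F)F)c3)c2)ccn1` carries cyclopropyl in its place, and in this assay compound 2 gives 20200 nM; the step is a 1.3-fold lower number from compound 1 to compound 2 (0.10 log units; within the scatter). Compound 3 `O=C(NCc1ccccc1)c1cc(Oc2cccc(NC(=S)Nc3cccc(C(F)(F)F)c3)c2)ccn1` carries benzyl, and in this assay compound 3 gives 7500 nM. Compound 3 stands lowest of the three numbers: from compound 2 the step is a 2.7-fold lower number from compound 2 to compound 3 (0.43 log units; beyond the scatter), and from compound 1 it is a 3.4-fold lower number from compound 1 to compound 3 (0.53 log units; beyond the scatter).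

Compound 4 `O=C(c1cc(Oc2cccc(NC(=S)Nc3cccc(C(F)(F)F)c3)c2)ccn1)N1CCCC1` is not yet measured; it differs from compound 3 by pyrrolidin-1-yl in place of benzylamino on a carbonyl carbon. For the measured compounds named here, two measured steps bear on this: a 2.7-fold lower number from compound 2 to compound 3 (0.43 log units; beyond the scatter) was a modest gain when benzyl entered, while a 1.3-fold lower number from compound 1 to compound 2 (0.10 log units; within the scatter) stayed within the scatter between methyl and cyclopropyl. Compound 4 lacks the six-membered aromatic ring that compound 3 carries, so the gain seen in a 2.7-fold lower number from compound 2 to compound 3 (0.43 log units; beyond the scatter) is expected to be given back in part and the number is expected to rise, a 2.0-fold higher number from compound 3 to compound 4 (0.30 log units; within the scatter). Compound 4 is estimated at 15000 nM in this assay, with a range from 6000 nM to 40000 nM.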

Compound 4, half-maximal inhibitory concentration: 19200 nM
Compound 4: the middle estimate sits 1.3-fold (0.11 log units) below what was measured, within the range that was stated.
By their numbers in this assay, from the lowest: compound 3; then compounds 4, 2 and 1 (each within the scatter of the next).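

For the compounds shown here, compound 4 is the first in this set without the amide hydrogen at this place, yet in this assay it sits level with the two smaller amides (a 1.1-fold lower number from compound 2 to compound 4 (0.02 log units; within the scatter)) and (a 1.3-fold lower number from compound 1 to compound 4 (0.12 log units; within the scatter)). Among these four, only the benzylamino group stands apart, and compound 3 remains the strongest (a 2.6-fold higher number from compound 3 to compound 4 (0.41 log units; beyond the scatter)). Nothing measured here explains either finding.

The change from benzylamino to pyrrolidin-1-yl removes the six-membered aromatic ring and the amide hydrogen together, so the compounds shown cannot separate the two; benzyl(methyl)amino on the same carbonyl carbon would keep the ring without that hydrogen. From the compounds shown here alone, it also remains open whether a longer chain, such as phenethylamino, would move the number further than benzylamino does.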